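The source may hold more compounds than are shown below. What is called first, only, known or untested is meant among the compounds shown, and "the series" means these compounds.

Working notes on the series.

In an assay for binding affinity to dual specificity mitogen-activated protein kinase kinase 4 (Homo sapiens), read by KINOMEscan, tested at 10 nM (on this read-out lower numbers stand for a stronger effect and higher numbers for a weaker effect at the one concentration tested), compound 1 `CCCS(=O)(=O)Nc1ccc(F)c(C(=O)c2n[nH]c3ncc(-c4ccc(N)cc4)cc23)c1F` gives 3.7%, compound 2 `CCCS(=O)(=O)Nc1ccc(F)c(C(=O)c2n[nH]c3ncc(-c4ccc(S(=O)(=O)NC)cc4)cc23)c1F` gives 14%, and compound 3 `CCCS(=O)(=O)Nc1ccc(F)c(C(=O)c2n[nH]c3ncc(-c4ccc(S(N)(=O)=O)cc4F)cc23)c1F` gives 9.4%. On these three numbers compound 3 stands second highest; its nearest neighbour is compound 2, with a number 4.6 percentage points lower from compound 2 to compound 3 (within the scatter), and its furthest is compound 1, with a number 5.7 percentage points higher from compound 1 to compound 3 (within the scatter). Going by the values given here, the only step beyond the scatter in this group is a number 10.3 percentage points higher from compound 1 to compound 2 (beyond the scatter).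

Compound 4 `CCCS(=O)(=O)Nc1ccc(F)c(C(=O)c2n[nH]c3ncc(-c4ccc(S(N)(=O)=O)cc4Cl)cc23)c1F` differs from compound 3 in one place: chloro in place of fluoro on an aromatic carbon.

Among the compounds with values here, no measured step exchanges one halogen for another, so none bears directly on this change. The two steps that end at compound 3 are both within the scatter, and they concern the sulfamoyl-bearing ring, not the halogen on it. With nothing pointing to a shift in either direction, no step beyond the scatter is expected in this assay. In this assay compound 4 is expected to give 10%, within 3% to 25%. The step expected is a number 0.6 percentage points higher from compound 3 to compound 4 (within the scatter).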

Compound 4, a percentage reported as activity, at one concentration (the size of the read-out at that concentration, not a potency): 23%
The estimate for compound 4 lay 13 percentage points below the measured number; the range from low to high includes it.
By their numbers in this assay, from the lowest: compounds 1, 3, 2 and 4 (each within the scatter of the next, the first and the last beyond it).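

In this assay, going by these compounds alone, the exchange of halogen on this aromatic carbon, ortho to a large group and meta to the sulfamoyl group, gives the first reading of this change, and a single heavy atom is enough to move the read-out: a number 13.6 percentage points higher from compound 3 to compound 4 (beyond the scatter). Against the other two ring variants the picture differs, with a number 19.3 percentage points higher from compound 1 to compound 4 (beyond the scatter) but only a number 9 percentage points higher from compound 2 to compound 4 (within the scatter), so the 2-chloro-4-sulfamoylphenyl ring separates clearly from the 4-aminophenyl ring and not from the 4-(methylsulfamoyl)phenyl ring. Nothing available accounts for the size of the halogen step.

Open, on these data alone, is whether a bromo, methyl or methoxy group on the same carbon would continue the step from fluoro to chloro. Also open, as far as these compounds go, is whether chloro has a similar effect on a ring carrying an amino or methylsulfamoyl group.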